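Aryl ketone swap from compound 3 to compound 4

This account rests on a few compounds, and the source may have more. Where it says the series, first, only, none or still open, it means among the compounds named here.

compound 1 `Cc1nc(C(=O)c2ccc(C)s2)c2sccc2n1`: > 10000 nM in a functional assay on CHO-K1 cells for antagonist activity at adenosine receptor A2b (Homo sapiens), read by FLIPR and calcium flux; on this read-out lower numbers stand for stronger inhibition and higher numbers for weaker inhibition; this is a limit of the assay, not a number.
compound 2 `Cc1ccc(C(=O)c2nc(NC(C)c3ccccn3)nc3ccsc23)s1`: 19 nM in this assay.
compound 3 `O=C(c1ccc(Cl)s1)c1nc(NCc2cccnc2)nc2ccsc12`: 487 nM in this assay.

Compound 3 holds the higher of the two numbers given in this assay. Going by the values given here, its nearest neighbour is compound 2, whose number lies lower by a margin well beyond the scatter; compound 2 and compound 3 differ in both the aryl group on the carbonyl and the amine side chain, so the pair shows only that the combination in compound 2 reads far lower. The value of compound 1 is a limit (the limit of > 10000 nM in this assay, at which 1 of the 3 values shown sits).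

Compound 4 `O=C(c1ccccc1)c1nc(NCc2cccnc2)nc2ccsc12` differs from compound 3 by phenyl in place of 5-chlorothiophen-2-yl on a carbonyl carbon. Among the compounds with values here, no pair of measured compounds differs in this place alone, so no measured step guides the move. For compound 4 a step of a 1.6-fold higher number from compound 3 to compound 4 (0.22 log units; within the scatter) in this assay is expected, a modest shift toward weaker inhibition that may not exceed the scatter. Compound 4 is estimated at 800 nM, with a range from 250 nM to 2500 nM.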

Compound 4, half-maximal inhibitory concentration: 511 nM
Beside the measured number, compound 4's estimate is 1.6-fold (0.19 log units) above it, and the stated range covers the measured number.
By their numbers in this assay, from the lowest: compound 2; then compounds 3 and 4 (each within the scatter of the next). At a limit, above all of these: compound 1.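

In this assay, going by these compounds alone, the exchange of 5-chlorothiophen-2-yl for phenyl on a carbonyl carbon gives a 1.0-fold higher number from compound 3 to compound 4 (0.02 log units; within the scatter), the first comparison that isolates a single place. With the amine side chain of compound 3 held constant, the two aryl groups cannot be told apart, so neither the sulfur nor the chlorine of the 5-chlorothiophen-2-yl group is needed to keep the reading of compound 3 at this place. Nothing shown gives a cause for this result.

As far as these compounds go, whether the same holds with other amine side chains stays open, as compound 2 differs from compound 3 in two places and its lower number cannot be assigned to either one. Also open, from the compounds shown here alone, is how a non-aromatic cyclohexyl group, or a phenyl carrying a methoxy group or a carboxylic acid, would read on this carbonyl.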